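The source may report more compounds than this note shows. Statements on the series, on what has been measured and on what is new or still open speak of the compounds shown alone.

Compound 1 `Nc1ncnc2c1c(-c1cnc3[nH]ccc3c1)nn2CCCCCC(=O)NO`: > 50000 nM, a limit
Compound 2 `Nc1nc2cc(-c3nn(CCCCCCCCC(=O)NO)c4ncnc(N)c34)ccc2o1`: 3240 nM
Compound 3 `Nc1nc2cc(-c3nn(CC(=O)NO)c4ncnc(N)c34)ccc2o1`: 12200 nM

All three compounds were tested in a functional assay on CNE-2 cells (Homo sapiens) for inhibition, read by MTT assay, with a stated time of 72 h; a lower number here means a stronger inhibitor, a higher number a weaker inhibitor. Compound 1 stands at the limit of > 50000 nM in this assay, at which 1 of the 3 values shown sits, so it has a limit and not a number.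

Compound 4 `Nc1ncnc2c1c(-c1cnc3[nH]ccc3c1)nn2CCCC(=O)NO` has not yet been measured. It differs from compound 1 in one place: hydroxycarbamoyl in place of 2-(hydroxycarbamoyl)ethyl on a saturated chain carbon, three bonds along the chain from an aromatic nitrogen. The 5-(hydroxycarbamoyl)pentyl chain of compound 1 thus becomes 3-(hydroxycarbamoyl)propyl, with hydroxycarbamoyl in place of 2-(hydroxycarbamoyl)ethyl on a saturated chain carbon, three bonds along the chain from an aromatic nitrogen.

For the measured compounds named here, no measured pair shows this change on its own, so the expectation rests on little. Going by the values given here, compound 3 gives 12200 nM and compound 2 gives 3240 nM, which shows only that real numbers can be obtained in this assay. A small move towards stronger inhibition is therefore expected, and compound 4 may well end at a limit again. The expected step is an at least 1.4-fold lower number from compound 1 to compound 4 (0.15 log units; that floor lies within the scatter). For compound 4 the estimated value is 35000 nM, with an expected range from 10000 nM to 100000 nM.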

Compound 4, half-maximal inhibitory concentration: > 150000 nM
Compound 4: only a limit was reported; the forecaster's own chance of this, stated with the estimate: 45%; middle value at least 4.2-fold (0.63 log units) away from the limit.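

Compound 1 and compound 4 are both reported in this assay only as limits and not as numbers, so the step between them cannot be read. The compounds shown leave open whether going from the 5-(hydroxycarbamoyl)pentyl chain to the 3-(hydroxycarbamoyl)propyl chain changes inhibition at all, and in which direction.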